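Amide nitrogen substituents on the shared core: cytotoxicity notes

The compounds below may be only part of what the source reports. "The series", "measured", "known", "first", "only" and "open" are said of these compounds alone.

Measured so far:
- compound 1, `C=CC1=C(C(=O)Nc2ccccc2)C(c2ccc(Cl)c(Cl)c2)OC1`: in a functional assay on HeLa cells (Homo sapiens) for cytotoxicity, read by MTT assay, with a stated time of 24 h (on this read-out higher numbers stand for weaker inhibition and lower numbers for stronger inhibition), compound 1 gives > 100000 nM, which is a limit of the assay and not a number.
- compound 2, `C=CC1=C(C(=O)NC(C)(C)C)C(c2ccc(Cl)c(Cl)c2)OC1`: in this assay compound 2 gives > 100000 nM, again a limit of the assay rather than a number.

Among the measured compounds shown here, compound 2 therefore stands only at a limit, and the one further value shown is also a limit: both sit at the limit of > 100000 nM in this assay, at which 2 of the 2 values shown sit. The step that the two limits leave unreadable from compound 1 to compound 2 is accordingly not readable in size or direction.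

Compound 3, `C=CC1=C(C(=O)Nc2ccccc2OC)C(c2ccc(Cl)c(Cl)c2)OC1`, differs from compound 2 by 2-methoxyphenyl in place of tert-butyl on an amide-type nitrogen. For the measured compounds named here, the only measured step that bears on this change is the unreadable one from compound 1 to compound 2, so no size or direction can be taken from it; what is known of the series gives no ground to expect a measurable value for compound 3 either.

Compound 3 is therefore expected to remain at the limit in this assay, with an estimate of 150000 nM and a range from 50000 nM to 500000 nM. The expected step, if a number were returned, is a step that the limit leaves unreadable from compound 2 to compound 3, but most likely compound 3 is expected to show only a limit.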

Compound 3, half-maximal inhibitory concentration: > 100000 nM
Compound 3 gave a limit, no number; the forecaster's own chance of this, stated with the estimate: 85%; the middle value does not contradict the limit.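

No new step can be read among compound 1, compound 2 and compound 3, since each gives only a limit and no number: the limit of > 100000 nM in this assay, at which 3 of the 3 values shown sit.

On these data alone, whether any substituent on the amide nitrogen of the shared core returns a readable value in this assay remains open.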